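Working notes: removing one bromo from compound 2

A few compounds are considered here, and "the series" means these few. Any claim that something is new, unique, unknown or untested is made for them only; others in the source may bear on it.

- Compound 1 `CCOc1ccc(C(=O)NNc2c(Br)cccc2Br)cc1` gives > 100000 nM (a limit)
- Compound 2 `CCOc1ccc(C(=O)NNc2ccc(Br)cc2Br)cc1` gives > 100000 nM (a limit)

In a toxicity assay on MDCK cells (Canis lupus familiaris) for cytotoxicity, read by CCK-8 assay, with a stated time of 48 h (a lower number here means that less compound is tolerated, a higher number that more compound is tolerated), compound 2 reads > 100000 nM, which is a limit and not a number. Compound 2 stands with compound 1 at the limit of > 100000 nM in this assay, at which 2 of the 2 values shown sit. Compound 3 `CCOc1ccc(C(=O)NNc2ccccc2Br)cc1` follows from compound 2 by hydrogen in place of bromo on an aromatic carbon, meta to a bromo group and para to a large group. Among the measured compounds shown here, no measured step gives a size, so no change beyond the scatter is expected in this assay. The estimated step is a number no higher from compound 2 to compound 3 (the limit leaves the size open). For compound 3 the expected value is 100000 nM, with an estimated range of 50000 nM to 200000 nM.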

Compound 3, half-maximal cytotoxic concentration: > 100000 nM
Compound 3 was reported as a limit (the forecaster's own chance of this, stated with the estimate: 85%); the middle value sits exactly at the limit.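

No new step can be read among compound 1, compound 2 and compound 3, as each result is a limit: the limit of > 100000 nM in this assay, at which 3 of the 3 values shown sit.

The compounds shown leave open whether hydrogen in place of bromo changes the read-out at all.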